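The source may report more compounds than this note shows. Statements on the series, on what has been measured and on what is new or still open speak of the compounds shown alone.

Measured in a functional assay on the whole organism with Mus musculus as the target, in the maximal electroshock model (on this read-out higher numbers stand for an effect only at larger amounts of compound and lower numbers for an effect already at smaller amounts), so far:

Compound 1 `Cc1cccc(-c2ccc(N3CCC(O)CC3)nn2)c1` gives 36 mg/kg
Compound 2 `OC1CCN(c2ccc(-c3cccc4ccccc34)nn2)CC1` gives 38 mg/kg
Compound 3 `O=COC1CCN(c2ccc(-c3ccc(Cl)cc3Cl)nn2)CC1` gives 24 mg/kg

Compound 3 stands at 24 mg/kg and this number lies within the usual scatter of the values of compound 1 and compound 2, so the data do not separate the three. Compound 4 `CCCC(=O)OC1CCN(c2ccc(-c3ccc(Cl)cc3Cl)nn2)CC1` is not yet measured. It carries one change from compound 3, propyl in place of hydrogen on a carbonyl carbon, counted as propyl in place of hydrogen on a carbonyl carbon in full. Among the measured compounds shown here, no measured pair shows this change, so the expectation is loose. It rests only on how closely compound 1 at 36 mg/kg and compound 2 at 38 mg/kg sit to compound 3 at 24 mg/kg despite their different structures. In this assay the expected step of a 1.1-fold higher number from compound 3 to compound 4 (0.03 log units; within the scatter) is estimated to stay within the scatter, with no firm direction. For compound 4 the estimated value is 26 mg/kg, with an expected range from 13 mg/kg to 52 mg/kg.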

Compound 4, dose for half-maximal effect: 50 mg/kg
Estimate against measurement, compound 4: 1.9-fold (0.28 log units) below; the measured number falls inside the stated range.
By their numbers in this assay, from the lowest: compounds 3, 1, 2 and 4 (each within the scatter of the next, the first and the last beyond it).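

In this assay, among the compounds shown here, propyl in place of hydrogen on a carbonyl carbon gives a 2.1-fold higher number from compound 3 to compound 4 (0.32 log units; beyond the scatter), the first comparison here of two compounds that differ in one place. So this position is not indifferent to what sits on it: with propyl, a larger amount of compound is needed for the effect. Nothing measured here accounts for the shift. One step says nothing about a trend with size. As far as these compounds go, whether a methyl or a longer chain such as hexyl on the same carbon would move the number further in this direction remains open.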